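Swapping the phenyl substituent on the pyrazoline carbon

The source may report more compounds than this note shows. Statements on the series, on what has been measured and on what is new or still open speak of the compounds shown alone.

Compound 1 `Cc1cc(O)c(C2=NN(c3ccc(S(N)(=O)=O)cc3)C(c3ccccc3O)C2)cc1Cl` is tested in a functional assay on HCC 2998 cells (Homo sapiens) for antiproliferative activity, with a stated time of 48 h (on this read-out lower numbers stand for stronger inhibition of growth and higher numbers for weaker inhibition of growth), where compound 1 gives 2130 nM. Among the two measured compounds this is the highest number, though its nearest neighbour, compound 2 `Cc1cc(O)c(C2=NN(c3ccc(S(N)(=O)=O)cc3)C(c3ccccc3Cl)C2)cc1Cl`, gives 2100 nM, a difference that falls within the scatter: a 1.0-fold lower number from compound 1 to compound 2 (0.01 log units; within the scatter). That step is the only one at the position now changed. In compound 3 `COc1ccc(C2CC(c3cc(Cl)c(C)cc3O)=NN2c2ccc(S(N)(=O)=O)cc2)c(OC)c1OC` the change is 2,3,4-trimethoxyphenyl in place of 2-hydroxyphenyl on a saturated ring carbon. Among the measured compounds shown here, the sole measured step at this position, from compound 1 to compound 2, shows that exchanging hydroxy for chloro on that ring left the number essentially unchanged, so the position tolerated at least one substitution without effect. The trimethoxy group is a larger alteration, yet nothing measured points either way. Compound 3 is therefore expected to sit close to compound 1, with the step of a 1.1-fold lower number from compound 1 to compound 3 (0.03 log units; within the scatter), giving an estimate of 2000 nM within a range from 600 nM to 7000 nM.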

Compound 3, concentration for 50% growth inhibition: 1840 nM
Beside the measured number, compound 3's estimate is 1.1-fold (0.04 log units) above it, within the range that was stated.
By their numbers in this assay, from the lowest: compounds 3, 2 and 1 (each within the scatter of the next).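

In this assay, the 2,3,4-trimethoxyphenyl group stays within the scatter of both earlier groups, the 2-hydroxyphenyl (a 1.2-fold lower number from compound 1 to compound 3 (0.06 log units; within the scatter)) and the 2-chlorophenyl (a 1.1-fold lower number from compound 2 to compound 3 (0.06 log units; within the scatter)). The earlier pair showed only that one substituent on this phenyl ring could be exchanged for another, whereas compound 3 shows that the saturated ring carbon also accepts a clearly bigger group, with more heavy atoms than the 2-hydroxyphenyl and no hydrogen-bond donor, and the numbers stay together. Nothing available explains why these three numbers stay so close. Still open, going by these compounds, is whether a phenyl ring carrying an amine or a carboxylic acid would also stay within the scatter here. Equally open, on these data alone, is whether a longer chain in place of the phenyl ring would do so.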